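Ester in Place of Acid on a Weak Series

The source may report more compounds than this note shows. Statements on the series, on what has been measured and on what is new or still open speak of the compounds shown alone.

Measured compounds:
- compound 1, `Cc1cc(C(=O)O)ccc1CN1C(C)CC[C@H](O[C@H](CO)c2cc(Cl)cc(Cl)c2)[C@@H]1c1ccccc1`: 130000 nM
- compound 2, `Cc1nc(C(=O)O)ccc1CN1CCC[C@H](O[C@H](CO)c2cc(Cl)cc(Cl)c2)[C@@H]1c1ccccc1`: 144000 nM
- compound 3, `Cc1cc(C(=O)O)ccc1CN1CC[C@H](OC(CO)c2cc(Cl)cc(Cl)c2)[C@@H]1c1ccccc1`: 185000 nM

All three were tested in an assay on isolated protein for activation of cGMP-dependent protein kinase 1 (Homo sapiens), read by ADP-Glo, with stated times of 30 min and 2 h; a lower number here means that less compound is needed, a higher number that more compound is needed for the effect. Compound 1 gives 130000 nM, compound 2 gives 144000 nM, and compound 3 gives 185000 nM. Compound 2 has the second highest of the three numbers; its nearest neighbour is compound 1 and its furthest is compound 3, yet both of those gaps lie within the usual scatter, so the three compounds cannot be ranked against one another on these numbers.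

Compound 4, `COC(=O)c1ccc(CN2CCC[C@H](O[C@H](CO)c3cc(Cl)cc(Cl)c3)[C@@H]2c2ccccc2)c(C)c1`, has not yet been measured. It differs from compound 2 in one place: a group of 11 heavy atoms (9 carbon, 2 oxygen; one six-membered aromatic ring of carbon only) in place of a group of 10 heavy atoms (7 carbon, 1 nitrogen, 2 oxygen; one six-membered aromatic ring with 1 hetero atom), on a saturated chain carbon bound to an amine nitrogen in a ring. Going by the values given here, no pair of measured compounds that differ in one place is available, so there is no measured step to lean on for this change. Given that, the step expected in this assay from compound 2 to compound 4 is none beyond the scatter, with wide uncertainty in either direction; the expected step is a 1.0-fold higher number from compound 2 to compound 4 (0.02 log units; within the scatter). Compound 4 is therefore estimated at 150000 nM, with a range from 60000 nM to 400000 nM.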

Compound 4, half-maximal effective concentration: > 200000 nM
Compound 4: a limit, no number (the forecaster's own chance of this, stated with the estimate: 25%); middle value at least 1.3-fold (0.12 log units) away from the limit.
By their numbers in this assay, from the lowest: compounds 1, 2 and 3 (each within the scatter of the next). At a limit, above all of these: compound 4.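

Compound 4 gives > 200000 nM in this assay, and this is a limit of the assay, not a number. The step is therefore only a floor, an at least 1.3-fold higher number from compound 2 to compound 4 (0.14 log units; that floor lies within the scatter), so the change on a saturated chain carbon bound to an amine nitrogen in a ring shows no lowering of the number, yet does not tell how far the number rises: the limit of > 200000 nM in this assay, at which 1 of the 4 values shown sits. The entering group has 0 hydrogen-bond donors where the leaving group has 1, and a six-membered aromatic ring of carbon only in place of one with 1 hetero atom, so these features change together in a single step.

Which of these features bears on the result stays open, as does the actual value of compound 4. The compounds shown also do not tell how an amide or a tetrazole in place of the ester would read.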